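Compound 4: the same atoms, a different drawn configuration

A few compounds are considered here, and "the series" means these few. Any claim that something is new, unique, unknown or untested is made for them only; others in the source may bear on it.

Measured in a functional assay on U-87MG ATCC cells (Homo sapiens) for cytotoxicity, read by MTT assay, with a stated time of 48 h; a higher number here means a weaker inhibitor, a lower number a stronger inhibitor:
- Compound 1 `C/C(=N\NC(=S)Nc1ccccc1I)c1ccccn1` gives 6.1 nM
- Compound 2 `CC(=NNC(=S)Nc1ccccc1)c1ccccn1` gives 1.4 nM
- Compound 3 `C/C(=N\NC(=S)Nc1ccccc1Cl)c1ccccn1` gives 2.6 nM

Compound 1 has the highest number of the three, which makes it the weakest inhibitor of this small set, and its gaps to both compound 2 and compound 3 lie beyond the usual scatter. The next compound, compound 4 `C/C(=N/NC(=S)Nc1ccccc1I)c1ccccn1`, changes no group at all. Its difference from compound 1 is this: the two compounds have the same atoms and bonds and differ only in configuration as drawn: 1 of 1 stereo elements differ; a double bond is drawn E in compound 1 and Z in compound 4. The two are therefore the same atoms and bonds with the double bond drawn the other way.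

Among the measured compounds shown here, the only measured step between two close relatives is a 2.3-fold lower number from compound 1 to compound 3 (0.37 log units; beyond the scatter). That step puts chloro in place of iodo, so it shows how far a single change can move the number here but says nothing direct about configuration. For the measured compounds named here, compound 2 is drawn without a configuration at that double bond, and no measured pair differs in configuration alone. The data therefore give no size for this kind of step, and no shift beyond the scatter is expected in this assay, though one cannot be excluded. The expected step is a 1.1-fold lower number from compound 1 to compound 4 (0.04 log units; within the scatter) and remains a rough estimate. Compound 4 is expected near 5.5 nM in this assay, with an estimated range from 2 nM to 15 nM as its likely span.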

Compound 4, half-maximal inhibitory concentration: 6.1 nM
Beside the measured number, compound 4's estimate is 1.1-fold (0.04 log units) below it; the measured number falls inside the stated range.
By their numbers in this assay, from the lowest: compounds 2 and 3 (each within the scatter of the next); then compounds 1 and 4 (each within the scatter of the next).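

The result gives the first measured size for a change of configuration in this assay: there is no change at the digits printed from compound 1 to compound 4 (within the scatter). This pair is an especially clean comparison, since nothing else separates the two structures: the fact that compounds 1 and 4 differ only in the configuration as drawn. For these two iodo compounds, the way the double bond is drawn therefore makes no difference beyond the scatter, whereas a change of group at the aromatic carbon did move the number, with a 2.3-fold lower number from compound 1 to compound 3 (0.37 log units; beyond the scatter).

The compounds shown leave open whether the same holds for the chloro compound, as compound 3 appears with only one drawn configuration and compound 2 with none at that double bond, and whether the two drawn forms of compound 1 and compound 4 stay distinct during the test. Also open, on these data alone, is how the number would respond if a methoxy group or a carboxylic acid stood in place of iodo, and whether configuration would still make so little difference with such a group present.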